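Swapping the Sulfonyl Aryl Toward Slower Clearance

The compounds below may be only part of what the source reports. "The series", "measured", "known", "first", "only" and "open" are said of these compounds alone.

Measured compounds:
- compound 1, `O=S(=O)(c1ccc(F)cc1)c1cnc2cc(F)ccc2c1-c1ccc(Cl)cc1`: 1.23 mL/min
- compound 2, `O=S(=O)(c1cc(Cl)cc(Cl)c1)c1cnc2cc(F)ccc2c1-c1ccc(F)cc1`: 0.18 mL/min
- compound 3, `COc1ccc(S(=O)(=O)c2cnc3cc(F)ccc3c2-c2ccc(Cl)cc2)cc1`: 1.28 mL/min

The three compounds were characterised in an ADME assay on microsomes from liver (Homo sapiens) for metabolic stability, tested at 2.5 uM; a lower number here means slower removal, a higher number faster removal of the compound. Compound 3 shows the highest of the three numbers, though its neighbour compound 1 is separated from it only by a 1.0-fold higher number from compound 1 to compound 3 (0.02 log units; within the scatter), a step that stays within the scatter. Compound 2, by contrast, sits well apart: compound 2 gives 0.18 mL/min, while compound 3 gives 1.28 mL/min, a gap beyond the scatter.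

Compound 4, `O=S(=O)(c1cc(Cl)cc(Cl)c1)c1cnc2cc(F)ccc2c1-c1ccc(Cl)cc1`, has not been measured in this assay. Relative to compound 3 it differs in one place: 3,5-dichlorophenyl in place of 4-methoxyphenyl on a sulfonyl sulfur. Going by the values given here, no measured step follows this exact change. Among the compounds with values here, the only step recorded, from compound 1 to compound 3, concerns a different substituent and was flat. What bears on compound 4 is that compound 2 carries the same 3,5-dichlorophenyl on its sulfonyl sulfur and gives the low number 0.18 mL/min, although compound 2 and compound 4 also differ elsewhere, so their pair is not a clean step.

Compound 4 is therefore expected to move toward compound 2 by about a 4.3-fold lower number from compound 3 to compound 4 (0.63 log units; beyond the scatter) in this assay. The estimated value of compound 4 is 0.3 mL/min, with a range from 0.1 mL/min to 0.9 mL/min.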

Compound 4, intrinsic clearance in a liver preparation (reported as CLH), per the amount of preparation that the assay uses: 0.13 mL/min
Compound 4: middle estimate off by 2.3-fold (0.36 log units), on the high side, and the stated range covers the measured number.
By their numbers in this assay, from the lowest: compounds 4 and 2 (each within the scatter of the next); then compounds 1 and 3 (each within the scatter of the next).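

In this assay, going by these compounds alone, the step at the sulfonyl sulfur now has a clear size: 3,5-dichlorophenyl in place of 4-methoxyphenyl gives a 9.8-fold lower number from compound 3 to compound 4 (0.99 log units; beyond the scatter), and 3,5-dichlorophenyl in place of 4-fluorophenyl gives a 9.5-fold lower number from compound 1 to compound 4 (0.98 log units; beyond the scatter), whereas the only earlier step between these aryl groups, a 1.0-fold higher number from compound 1 to compound 3 (0.02 log units; within the scatter), was flat. Within this small set, the number therefore depends on 3,5-dichlorophenyl being present, and not on which of the two singly substituted phenyl groups it replaces, while chloro in place of fluoro on an aromatic carbon elsewhere in the molecule gives a 1.4-fold lower number from compound 2 to compound 4 (0.14 log units; within the scatter), a step that stays within the scatter and leaves compound 2 and compound 4 together at the low end. Nothing measured here explains why the 3,5-dichlorophenyl compounds stand so far from the other two.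

The compounds shown leave open whether both chloro groups are needed, since none carries a phenyl with a single chloro on the sulfonyl sulfur. They also leave open how this position would respond to an amine or a carboxylic acid on that aryl ring.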